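The compounds below may be only part of what the source reports. "The series", "measured", "known", "first", "only" and "open" are said of these compounds alone.

Compound 2 `CNC(=O)c1cc(C(=O)NC2CC2)cn(CC2CCCOC2)c1=O` is the starting point of this step. In a physicochemical assay for solubility (on this read-out lower numbers stand for lower solubility and higher numbers for higher solubility), compound 2 gives >= 131 ug/mL, a limit of the assay rather than a measured number. Compound 1 `CNC(=O)c1cc(C(=O)NCCC2CCOCC2)cn(Cc2ccccc2)c1=O` also sits at a limit, giving >= 127 ug/mL. Compound 3 `CNC(=O)c1cc(C(=O)NCC(C)C)cn(Cc2ccccc2)c1=O` gives 43 ug/mL, a true number. Among the measured compounds shown here, the only measured step, an at least 2.9-fold lower number from compound 1 to compound 3 (0.47 log units; beyond the scatter), shows that replacing (oxan-4-yl)methyl with isopropyl pulled the solubility down at least modestly, with the starting value at the limit of >= 127 ug/mL in this assay, at which 1 of the 3 values shown sits.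

Compound 4 `CNC(=O)c1cc(C(=O)NC2CC2)cn(Cc2cccc3cn[nH]c23)c1=O` differs from compound 2 by 1H-indazol-7-yl in place of oxan-3-yl on a saturated chain carbon bound to an aromatic nitrogen. This change sits on a different part of the shared core than the measured step and is of a different kind, so the measured step is only a loose guide; what it does suggest is that removing the oxygen-containing saturated ring has gone together with lower solubility. On that basis compound 4 is expected to be less soluble than the limit reached by compound 2, with the step estimated as an at least 3.7-fold lower number from compound 2 to compound 4 (0.57 log units; beyond the scatter), downward. The solubility of compound 4 is therefore estimated at about 35 ug/mL, within a range from 8 ug/mL to 130 ug/mL.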

Compound 4, solubility: >= 181 ug/mL
Compound 4 gave a limit, no number; the forecaster's own chance of this, stated with the estimate: 15%; middle value at least 5.1-fold (0.71 log units) away from the limit.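

Compound 2 and compound 4 both give limits rather than numbers in this assay, so the step between them cannot be read. The compounds shown leave open whether 1H-indazol-7-yl in place of oxan-3-yl raises solubility, lowers it or leaves it unchanged.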